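Pentyl in Place of Cyclopropyl on a Shared Alkyne Core

This account rests on a few compounds, and the source may have more. Where it says the series, first, only, none or still open, it means among the compounds named here.

compound 1 `CC(=O)OCC(CCn1cc(C#Cc2cc(F)cc(F)c2)c(=O)n(C(=O)c2ccccc2)c1=O)COC(C)=O` — > 100000 nM
compound 2 `CC(=O)OCC(CCn1cc(C#Cc2ccc(Br)cc2)c(=O)n(C(=O)c2ccccc2)c1=O)COC(C)=O` — > 100000 nM
compound 3 `CC(=O)OCC(CCn1cc(C#CC2CC2)c(=O)n(C(=O)c2ccccc2)c1=O)COC(C)=O` — > 100000 nM

Three measured compounds share one core and differ only in the group on the triple-bonded carbon. In a functional assay on SW-620 cells (Homo sapiens) for antiproliferative activity, read by MTT assay, with a stated time of 72 h (a higher number here means a weaker inhibitor, a lower number a stronger inhibitor), compound 1 gives no number but only the limit of the assay, > 100000 nM. Compound 2 likewise stops at a limit, > 100000 nM. Compound 3 stands at a limit as well, > 100000 nM. Because all three values sit at the limit of > 100000 nM in this assay, at which 3 of the 3 values shown sit, the steps a step that the two limits leave unreadable from compound 1 to compound 2, a step that the two limits leave unreadable from compound 1 to compound 3 and a step that the two limits leave unreadable from compound 2 to compound 3 cannot be read in size or direction; compound 3 is therefore neither stronger nor weaker than its two neighbours on the numbers at hand.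

Compound 4 `CCCCCC#Cc1cn(CCC(COC(C)=O)COC(C)=O)c(=O)n(C(=O)c2ccccc2)c1=O` differs from compound 3 by pentyl in place of cyclopropyl on a triple-bonded carbon. All three measured steps bear on this change, since each swaps the group on the same triple-bonded carbon, yet none of them yields a readable size. The step expected in this assay from compound 3 to compound 4 is accordingly estimated as a number no higher from compound 3 to compound 4 (the limit leaves the size open), with no movement beyond the scatter to be anticipated. Compound 4 is therefore expected to give about 100000 nM, with a range from 30000 nM to 300000 nM, and most likely again only a limit.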

Compound 4, half-maximal inhibitory concentration: 40700 nM
Compound 4: middle estimate off by 2.5-fold (0.39 log units), on the high side; the range from low to high includes it.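

In this assay, for the compounds shown here, the group on the triple-bonded carbon can move the read-out: pentyl in place of cyclopropyl gives an at least 2.4-fold lower number from compound 3 to compound 4 (0.39 log units; beyond the scatter), the first step at this position whose direction can be read. The open pentyl chain also stands apart from both aromatic groups, with pentyl in place of 4-bromophenyl giving an at least 2.4-fold lower number from compound 2 to compound 4 (0.39 log units; beyond the scatter) and pentyl in place of 3,5-difluorophenyl giving an at least 2.4-fold lower number from compound 1 to compound 4 (0.39 log units; beyond the scatter). Compound 4 alone gives a number, so these three steps fix only a smallest size, and because compounds 1, 2 and 3 all stop at the same limit, those three cannot be ranked against one another: the limit of > 100000 nM in this assay, at which 3 of the 4 values shown sit.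

The compounds shown leave open whether the step follows from the chain itself or from the loss of a ring, as pentyl differs from cyclopropyl in both respects, and a cyclopentyl group or a longer chain such as octyl would bear on that question. Going by these compounds, it also remains open whether the step would survive on a pentyl chain carrying an amine or a carboxylic acid.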